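The source may report more compounds than this note shows. Statements on the series, on what has been measured and on what is new or still open speak of the compounds shown alone.

Measured compounds in a functional assay on HEK293 cells for antagonist activity at transient receptor potential cation channel subfamily V member 1 (Homo sapiens), read by calcium flux; a higher number here means a weaker inhibitor, a lower number a stronger inhibitor:

compound 1, `Cc1cccc(C)c1Nc1nc2c(Nc3ccc(C(F)(F)F)cc3)ncnc2s1` — compound 1 gives 23 nM
compound 2, `Cc1ccc(Nc2ncnc3sc(Nc4c(Cl)cccc4Cl)nc23)cc1` — compound 2 gives 33 nM
compound 3, `FC(F)(F)c1ccc(Nc2nc(N3CCCC3)nc3sc(Nc4c(Cl)cccc4Cl)nc23)cc1` — compound 3 gives 12 nM

Compound 3 carries the lowest number of the three in this assay. Its gap to compound 1 is within the scatter, so no order can be read between those two; its gap to compound 2 lies beyond the scatter.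

Compound 4, `CC(C)Nc1nc(Nc2ccc(C(F)(F)F)cc2)c2nc(Nc3c(Cl)cccc3Cl)sc2n1`, is not yet measured. It differs from compound 3 in one place: isopropylamino in place of pyrrolidin-1-yl on an aromatic carbon. Within the data shown here, the change swaps a ring for an open chain of nearly the same size and adds one hydrogen-bond donor; no measured pair shows this exact change, so there is nothing to calibrate a step against.

Among the measured compounds shown here, with no comparable step among the measured compounds, the working expectation for this assay is no step beyond the scatter, in either direction. The estimate for compound 4 is 15 nM, in the range 5 nM to 45 nM, which is expected to mean a step of a 1.3-fold higher number from compound 3 to compound 4 (0.10 log units; within the scatter).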

Compound 4, half-maximal inhibitory concentration: 13 nM
Compound 4: middle estimate off by 1.2-fold (0.06 log units), on the high side, within the range that was stated.
By their numbers in this assay, from the lowest: compounds 3, 4, 1 and 2 (each within the scatter of the next, the first and the last beyond it).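

In this assay the step from pyrrolidin-1-yl to isopropylamino, on the aromatic carbon between two ring nitrogen atoms, is a 1.1-fold higher number from compound 3 to compound 4 (0.03 log units; within the scatter) and gives the series its first comparison of compounds differing in one place. At this position, then, replacing the ring with an open chain and gaining a hydrogen-bond donor produce no readable difference in this pair. No measurement in hand bears on why the two groups read alike.

As far as these compounds go, how far this holds for larger or differently built groups stays open, such as morpholin-4-yl, a longer alkylamino chain or a carboxylic acid on the same carbon. Among these compounds, also open is whether an amine here matters at all, since no single-place pair sets either group against a plain ring hydrogen.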